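Swapping fluoro for methyl on the pendant aryl ring

The source may hold more compounds than are shown below. What is called first, only, known or untested is meant among the compounds shown, and "the series" means these compounds.

Of the compounds shown here, two sharing one core have been measured in a functional assay on NCI-H460 cells (Homo sapiens) for antiproliferative activity, read by MTT assay, with a stated time of 48 h; on this read-out higher numbers stand for weaker inhibition and lower numbers for stronger inhibition. Compound 1 `COc1ccc(-c2nc3cccc(-c4cc(OC)c(OC)c(OC)c4)c3o2)cc1` gives 3500 nM. Compound 2 `COc1cc(-c2cccc3nc(-c4cccc(F)c4)oc23)cc(OC)c1OC` gives 3300 nM. The single measured step, a 1.1-fold lower number from compound 1 to compound 2 (0.03 log units; within the scatter), comes from putting 3-fluorophenyl in place of 4-methoxyphenyl on an aromatic carbon, and on the numbers shown compound 2 and compound 1 stand within the scatter of each other, so neither can be called the stronger inhibitor.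

Compound 3 `COc1cc(-c2cccc3nc(-c4cccc(C)c4)oc23)cc(OC)c1OC` differs from compound 2 by methyl in place of fluoro on an aromatic carbon. The change sits on the same pendant ring that was altered between compound 1 and compound 2, so that step is the one that bears on it; it was small, and a group of one heavy atom replaces another group of one heavy atom, with no ring, no hydrogen-bond donor and no hydrogen-bond acceptor gained or lost.

The expected step, no change at the digits printed from compound 2 to compound 3 (within the scatter), is therefore none beyond the scatter. Compound 3 is estimated at 3300 nM, within a range from 1500 nM to 7500 nM.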

Compound 3, half-maximal inhibitory concentration: > 25000 nM
Compound 3: no number, only a limit (the forecaster's own chance of this, stated with the estimate: 3%); middle value at least 7.5-fold (0.87 log units) away from the limit.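

The earlier pair suggested that this pendant ring tolerates change, yet in this assay the change from 3-fluorophenyl to 3-methylphenyl gives an at least 7.5-fold higher number from compound 2 to compound 3 (0.87 log units; beyond the scatter), so swapping one heavy atom at this place, with no ring, hydrogen-bond donor or hydrogen-bond acceptor gained or lost, is enough to separate two compounds beyond the scatter. The comparison with the 4-methoxyphenyl group points the same way, with an at least 7.1-fold higher number from compound 1 to compound 3 (0.85 log units; beyond the scatter), which leaves the 3-methylphenyl compound apart from the two pendant rings that read alike. For compound 3 the reading is a limit of the assay and not a number, so the true size of both steps stays unknown: the limit of > 25000 nM in this assay, at which 1 of the 3 values shown sits.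

On these data alone, whether a chloro group, a hydroxyl group or an amine in this same place would read like fluoro or like methyl stays open. Three compounds also cannot tell whether the gap between methyl and fluoro holds on a different core or in a different cell line.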